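Changing the Sulfonyl Substituent of Compound 3

A few compounds are considered here, and "the series" means these few. Any claim that something is new, unique, unknown or untested is made for them only; others in the source may bear on it.

In a functional assay on DU-145 cells (Homo sapiens) for inhibition, read by trypan blue exclusion, with a stated time of 96 h (on this read-out lower numbers stand for stronger inhibition of growth and higher numbers for weaker inhibition of growth), compound 3 (`COc1ccccc1/C=C(\C(=O)c1ccc(Cl)cc1)S(=O)(=O)c1ccc(C)cc1`) gives 1000 nM. Compound 1 (`COc1ccccc1/C=C(\C(=O)c1ccc(Br)cc1)S(=O)(=O)c1ccc(C)cc1`) gives 1000 nM, and compound 2 (`COc1ccccc1/C=C(\C(=O)c1ccc(Cl)cc1)S(=O)(=O)Cc1ccc(Cl)c(Cl)c1`) gives 1000 nM, so all three stand level. Compound 4 (`COc1ccccc1/C=C(\C(=O)c1ccc(Cl)cc1)S(=O)(=O)Cc1ccc(Cl)cc1`) differs from compound 3 in one place: 4-chlorobenzyl in place of 4-methylphenyl on a sulfonyl sulfur. In words, 4-chlorobenzyl replaces 4-methylphenyl on a sulfonyl sulfur. The most relevant measured step, 4-methylphenyl in place of 3,4-dichlorobenzyl on that sulfur, shows no change at the digits printed from compound 2 to compound 3 (within the scatter). Chloro in place of bromo on an aromatic carbon shows no change at the digits printed from compound 1 to compound 3 (within the scatter). Neither step goes beyond the scatter, so the expected result is no change at the digits printed from compound 3 to compound 4 (within the scatter), with no direction favoured. Compound 4 is estimated at 1000 nM, with an expected range of 400 nM to 2500 nM.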

Compound 4, concentration for 50% growth inhibition: 25000 nM
Estimate against measurement, compound 4: 25-fold (1.40 log units) below; the measured number lies above the stated range.
By their numbers in this assay, from the lowest: compounds 1, 2 and 3 (each within the scatter of the next); then compound 4.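

This sulfonyl position is sensitive after all: in this assay, 4-chlorobenzyl in place of 4-methylphenyl on the sulfonyl sulfur gives a 25-fold higher number from compound 3 to compound 4 (1.40 log units; beyond the scatter) and weakens growth inhibition. Losing a single chloro from the benzyl group matters just as much, with a 25-fold higher number from compound 2 to compound 4 (1.40 log units; beyond the scatter) for hydrogen in place of chloro on an aromatic carbon, so the level values of the earlier compounds hid a steep local change. Nothing at hand accounts for this difference.

Open, as far as these compounds go, is whether a benzyl group with no chloro, or one carrying an amine or a carboxylic acid in place of that chloro, would stand with compound 2 or with compound 4.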